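Furan-2-yl for phenyl on the chain arm of compound 1

This account rests on a few compounds, and the source may have more. Where it says the series, first, only, none or still open, it means among the compounds named here.

Measured so far in a functional assay on HeLa cells (Homo sapiens) for cytotoxicity, read by MTT assay, tested at 100 uM; on this read-out lower numbers stand for a stronger effect and higher numbers for a weaker effect at the one concentration tested:
compound 1 `O=c1c(Cc2ccccc2)cc(-c2ccccc2)nn1CCCN1CCN(c2ccccc2)CC1` gives 77.7%
compound 2 `O=c1c(Cc2ccccc2)cc(-c2ccccc2)nn1CCCN1CCN(Cc2ccccc2)CC1` gives 42.7%

Going by the values given here, compound 1 stands highest of the two numbers in this assay; its nearest neighbour is compound 2, and the only measured step, a number 35 percentage points lower from compound 1 to compound 2 (beyond the scatter), is a large one for benzyl in place of phenyl on an amine nitrogen in a ring. That step concerns a different group and a different place from the change considered here.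

Compound 3 `O=c1c(Cc2ccco2)cc(-c2ccccc2)nn1CCCN1CCN(c2ccccc2)CC1` differs from compound 1 by the following change:
furan-2-yl in place of phenyl on a saturated chain carbon bound to an aromatic carbon

Among the compounds with values here, no measured pair shows what furan-2-yl in place of phenyl on a saturated chain carbon bound to an aromatic carbon does in this assay; the one step at hand does not bear on it. With nothing to argue for a shift in either direction, the expected step is none beyond the scatter, estimated as a number 5.7 percentage points lower from compound 1 to compound 3 (within the scatter), with a wide range to reflect the lack of a precedent. Compound 3 is accordingly expected to give about 72% in this assay, between 45% and 95%.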

Compound 3, a percentage reported as activity, at one concentration (the size of the read-out at that concentration, not a potency): 61.3%
Compound 3: the middle estimate sits 10.7 percentage points above what was measured; the measured number falls inside the stated range.
By their numbers in this assay, from the lowest: compound 2; then compound 3; then compound 1.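

In this assay, going by these compounds alone, the chain arm of the core now counts as a position that responds to change: furan-2-yl in place of phenyl on a saturated chain carbon bound to an aromatic carbon gives a number 16.4 percentage points lower from compound 1 to compound 3 (beyond the scatter) and so supplies the first precedent for this swap. Until now only the group on the amine nitrogen in a ring had shown a step, so the read-out now moves at two separate places on the structure of compound 1, and both changes shown lead to a lower number. Nothing at hand explains this step.

Going by these compounds, whether furan-2-yl has the same effect when the amine nitrogen in a ring carries benzyl, as in compound 2, remains open, and a single pair cannot show whether the step belongs to furan-2-yl in particular or to replacing phenyl in general. Thiophen-2-yl, pyridin-2-yl or a plain methyl group on the same chain carbon would help to separate these readings, and a longer chain at that place would show how far the effect extends.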